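The compounds below may be only part of what the source reports. "The series", "measured", "known", "first", "only" and "open" are said of these compounds alone.

Measured in a physicochemical assay for solubility, in phosphate buffer, with a stated time of 24 h, at pH 7.4, tested at 100 uM; on this read-out lower numbers stand for lower solubility and higher numbers for higher solubility:
- compound 1 `O=C(NCc1ccc(S(=O)(=O)c2cncc(C(F)(F)F)c2)cc1)N1Cc2ccncc2C1`: 83000 nM
- compound 2 `O=C(NCc1ccc(S(=O)(=O)c2cc(F)cc(F)c2)cc1)N1Cc2ccncc2C1`: 16000 nM
- compound 3 `O=C(NCc1ccc(S(=O)(=O)C2CCN(C3COC3)CC2)cc1)N1Cc2ccncc2C1`: 121000 nM

Compound 3 stands level with compound 1 within the scatter, as the step of a 1.5-fold higher number from compound 1 to compound 3 (0.16 log units; within the scatter) shows. Compound 2 is clearly lower than both, with steps a 5.2-fold lower number from compound 1 to compound 2 (0.71 log units; beyond the scatter) and a 7.6-fold higher number from compound 2 to compound 3 (0.88 log units; beyond the scatter).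

Next is compound 4 `O=C(NCc1ccc(S(=O)(=O)N2CCC(N3CCCC3)CC2)cc1)N1Cc2ccncc2C1`, with 4-(pyrrolidin-1-yl)piperidin-1-yl in place of 1-(oxetan-3-yl)piperidin-4-yl on a sulfonyl sulfur.

All three measured steps change the group at this same place, but only the aromatic groups of compound 1 and compound 2 are exchanged for the group of compound 3. Among the measured compounds shown here, no measured step swaps one group with non-aromatic rings for another, so the evidence is indirect. The largest step at this place is modest, and the step of a 1.5-fold higher number from compound 1 to compound 3 (0.16 log units; within the scatter) stays within the scatter. No clear change is therefore expected in this assay, in either direction. The expected change is a 1.1-fold lower number from compound 3 to compound 4 (0.04 log units; within the scatter), which is not beyond the scatter. For compound 4 the estimated value is 110000 nM, with an expected range of 60000 nM to 180000 nM.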

Compound 4, solubility: 6200 nM
Compound 4: the middle estimate sits 18-fold (1.25 log units) above what was measured, outside the stated range (below it).
By their numbers in this assay, from the lowest: compound 4; then compound 2; then compounds 1 and 3 (each within the scatter of the next).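

In this assay, a non-aromatic group on this sulfonyl sulfur does not by itself keep the number high: two groups that each hold a six-membered non-aromatic ring sit far apart (a 20-fold lower number from compound 3 to compound 4 (1.29 log units; beyond the scatter)). Compound 4 also lies under both compounds with aromatic groups (a 2.6-fold lower number from compound 2 to compound 4 (0.41 log units; beyond the scatter); a 13-fold lower number from compound 1 to compound 4 (1.13 log units; beyond the scatter)), so the compounds at this place do not divide into aromatic and non-aromatic sets. No measurement shown here accounts for the drop.

The step exchanges the oxetan-3-yl part for a pyrrolidin-1-yl part and also replaces the piperidin-4-yl part with a piperidin-1-yl part, so the compounds shown cannot assign the drop to either change. A 4-(morpholin-4-yl)piperidin-1-yl group at the same place would keep the piperidin-1-yl part and swap only the pyrrolidine ring.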